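Propyl versus cyclopropylmethyl on the amine across two cores

The compounds below may be only part of what the source reports. "The series", "measured", "known", "first", "only" and "open" are said of these compounds alone.

Measured so far:
compound 1 `CCCN(Cc1ccc(OCCN2C(=O)CCC2=O)c(C)c1)[C@@H](CC(=O)O)c1ccc(Cl)cc1` — 97%
compound 2 `Cc1cc(CN(CC2CC2)[C@@H](CC(=O)O)c2ccc(Cl)cc2)ccc1OCCN1C(=O)CCC1=O` — 90%
compound 3 `CCCN(Cc1ccc(OCCn2c(=O)ccn(C)c2=O)c(C)c1)C(CC(=O)O)c1ccc(Cl)cc1` — 30%

In an ADME assay on liver (Homo sapiens) for metabolic stability, read by LC-MS, using microsomes and NADPH (on this read-out lower numbers stand for a less stable compound and higher numbers for a more stable compound), compound 1 gives 97% and compound 2 gives 90%. The step between them, (cyclopropyl in place of ethyl on a saturated chain carbon bound to an amine nitrogen), amounts to a number 7 percentage points lower from compound 1 to compound 2 (within the scatter). Compound 3 carries a different core; the difference between the two cores is not broken down here. In this assay compound 3 gives 30%, which against the values of compound 1 and compound 2 stands far lower, beyond the scatter in both cases.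

Compound 4 `Cc1cc(CN(CC2CC2)C(CC(=O)O)c2ccc(Cl)cc2)ccc1OCCn1c(=O)ccn(C)c1=O` is not yet measured. It differs from compound 3 by cyclopropyl in place of ethyl on a saturated chain carbon bound to an amine nitrogen, the same change that separates compound 1 from compound 2, at the same place. The expectation for the step from compound 3 to compound 4 is therefore set beside the earlier one: a number 3 percentage points lower from compound 3 to compound 4 (within the scatter), a step expected to stay small because a number 7 percentage points lower from compound 1 to compound 2 (within the scatter) was within the scatter. The estimate for compound 4 in this assay is 27%, with a range expected from 12% to 45%.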

Compound 4, percent of the compound remaining: 32%
The estimate for compound 4 lay 5 percentage points below the measured number; measured number inside the range.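

In this assay, the same change on the second core gives a number 2 percentage points higher from compound 3 to compound 4 (within the scatter), and the comparison with the first core shows no difference between the two steps: the same change on two cores in this assay, a number 7 percentage points lower (within the scatter) from compound 1 to compound 2 and a number 2 percentage points higher (within the scatter) from compound 3 to compound 4, 9 percentage points apart, within the scatter of two such steps On these two cores, replacing propyl with cyclopropylmethyl therefore carries over with no step beyond the scatter, on the core of compound 1 as on the core of compound 3. This rests on two pairs in a single assay: it does not show that the change would stay as small on a third core, and it says nothing about why the values of the two cores stand so far apart.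

As far as these compounds go, how a longer chain such as butyl, or a larger ring such as cyclobutylmethyl, would read in the place of propyl stays open. From the compounds shown here alone, all four compounds also keep the carboxylic acid, so the reading in this assay with an amide in its place is equally open.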